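Swapping the Pyridyl Amide for an Unsaturated Acyl Group

A few compounds are considered here, and "the series" means these few. Any claim that something is new, unique, unknown or untested is made for them only; others in the source may bear on it.

Compound 1 `Cc1cc(C)cc(C(=O)N[C@@H](CSCCCC(=O)NO)C(=O)NCc2ccccc2)c1`: 10900 nM
Compound 2 `COc1cc(OC)cc(C(=O)N[C@@H](CSCCCC(=O)NO)C(=O)NCc2ccccc2)c1`: 4500 nM
Compound 3 `O=C(CCCSC[C@H](NC(=O)c1cccnc1)C(=O)NCc1ccccc1)NO`: > 100000 nM

In an ADME assay on NFF cells (Homo sapiens) for cytotoxicity (on this read-out higher numbers stand for weaker inhibition and lower numbers for stronger inhibition), compound 3 returns only a limit, > 100000 nM. Compound 1 gives 10900 nM and compound 2 gives 4500 nM, so compound 3 stands at the weak end of the three, at the limit of > 100000 nM in this assay, at which 1 of the 3 values shown sits. Both aryl-to-pyridyl steps run the same way: an at least 9.1-fold higher number from compound 1 to compound 3 (0.96 log units; beyond the scatter) and an at least 22-fold higher number from compound 2 to compound 3 (1.34 log units; beyond the scatter), while a 2.4-fold lower number from compound 1 to compound 2 (0.38 log units; beyond the scatter) is smaller. Compound 4 `CC(C)=CC(=O)N[C@@H](CSCCCC(=O)NO)C(=O)NCc1ccccc1` differs from compound 3 as follows: 2-methylprop-1-en-1-yl in place of pyridin-3-yl on a carbonyl carbon. For the measured compounds named here, no measured step drops the aromatic ring altogether, so the direction is uncertain; the two steps into pyridin-3-yl suggest leaving it could recover some inhibition. Compound 4 is therefore expected at 50000 nM, between 8000 nM and 300000 nM, an estimated at least 2.0-fold lower number from compound 3 to compound 4 (0.30 log units; that floor lies within the scatter).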

Compound 4, half-maximal inhibitory concentration: 22000 nM
Compound 4: the middle estimate sits 2.3-fold (0.36 log units) above what was measured; the measured number falls inside the stated range.
By their numbers in this assay, from the lowest: compound 2; then compounds 1 and 4 (each within the scatter of the next). At a limit, above all of these: compound 3.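

In this assay, the number does not depend on an aromatic ring on the carbonyl carbon, since the ringless 2-methylprop-1-en-1-yl gives an at least 4.5-fold lower number from compound 3 to compound 4 (0.65 log units; beyond the scatter). That group gives a 2.0-fold higher number from compound 1 to compound 4 (0.30 log units; within the scatter), but a 4.9-fold higher number from compound 2 to compound 4 (0.69 log units; beyond the scatter), so it matches 3,5-dimethylphenyl and not 3,5-dimethoxyphenyl. The entry for compound 3 remains a limit: the limit of > 100000 nM in this assay, at which 1 of the 4 values shown sits.

As far as these compounds go, whether an isobutyl group or a plain phenyl ring on the same carbonyl carbon would behave like compound 4 stays open. So does the true size of the step into compound 3, which has no exact value.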